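Benzyl amide variations with no measurable cytotoxicity

A few compounds are considered here, and "the series" means these few. Any claim that something is new, unique, unknown or untested is made for them only; others in the source may bear on it.

Measured compounds:
compound 1 `C=CC1=C(C(=O)NCc2ccc(C)cc2)C(c2ccc(F)cc2)OC1`: > 100000 nM
compound 2 `C=CC1=C(C(=O)NCc2ccccc2F)C(c2ccc(F)cc2)OC1`: > 100000 nM
compound 3 `C=CC1=C(C(=O)NCc2ccc(C)cc2)C(c2ccc(OC)cc2)OC1`: > 100000 nM

In a functional assay on A549 cells (Homo sapiens) for cytotoxicity, read by MTT assay, with a stated time of 24 h (on this read-out lower numbers stand for stronger inhibition and higher numbers for weaker inhibition), compound 1 gives > 100000 nM, which is a limit of the assay and not a number. In this assay compound 2 likewise gives only the limit > 100000 nM. In this assay compound 3 also gives only the limit > 100000 nM. The change 2-fluorophenyl in place of 4-methylphenyl on a saturated chain carbon bound to an amide-type nitrogen therefore gives a step that the two limits leave unreadable from compound 1 to compound 2. The two cores differ by methoxy in place of fluoro on an aromatic carbon, and the step that the two limits leave unreadable from compound 1 to compound 3 is equally unreadable. Compound 4 `C=CC1=C(C(=O)NCc2ccccc2F)C(c2ccc(OC)cc2)OC1` carries the same change as made from compound 1 to compound 2, namely (2-fluorophenyl in place of 4-methylphenyl on a saturated chain carbon bound to an amide-type nitrogen), at the same place. Because (the limit of > 100000 nM in this assay, at which 3 of the 3 values shown sit), nothing here points to activity appearing. The step from compound 3 to compound 4 in this assay is expected to be a step that the limit leaves unreadable from compound 3 to compound 4. Compound 4 is therefore estimated at 150000 nM, most likely reported only as a limit, with a range from 50000 nM to 500000 nM.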

Compound 4, half-maximal inhibitory concentration: > 100000 nM
Compound 4 gave a limit, no number; the forecaster's own chance of this, stated with the estimate: 85%; the middle value is on the limit's open side.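

Compound 4 also gives only a limit, so neither step into it, from compound 3 or from compound 2, can be read in this assay. The compounds shown leave open which change to the shared core, if any, would bring measurable cytotoxicity: the limit of > 100000 nM in this assay, at which 4 of the 4 values shown sit.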